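This account rests on a few compounds, and the source may have more. Where it says the series, first, only, none or still open, it means among the compounds named here.

Going by the values given here, in a functional assay on KB cells (Homo sapiens) for cytotoxicity, read by MTT assay, with a stated time of 48 h (on this read-out higher numbers stand for weaker inhibition and lower numbers for stronger inhibition), compound 1 (`CCn1cc(-c2nc3ccccc3[nH]2)c(=O)c2cc(F)c(N3CCNCC3)nc21`) gives 2000 nM as the lowest of three numbers so far. Compound 3 (`CCn1cc(-c2nc3ccc([N+](=O)[O-])cc3s2)c(=O)c2cc(F)c(N3CCNC(C)C3)c(F)c21`) gives 4700 nM and compound 2 (`CCn1cc(-c2nc3ccccc3s2)c(=O)c2cc(F)c(N3CCNC(C)C3)c(F)c21`) gives 24300 nM on a different core. Compound 4 (`CCn1cc(-c2nc3ccc(N)cc3[nH]2)c(=O)c2cc(F)c(N3CCNCC3)nc21`) differs from compound 1 by amino in place of hydrogen on an aromatic carbon in one place: amino in place of hydrogen on an aromatic carbon. The nearest measured step is a 5.2-fold lower number from compound 2 to compound 3 (0.71 log units; beyond the scatter) with nitro in place of hydrogen on an aromatic carbon. That modest step involves another group on another core, so it is only a weak guide to size and direction. The expected step in this assay is a 1.3-fold lower number from compound 1 to compound 4 (0.12 log units; within the scatter) and stays within the scatter. For compound 4 the estimate is 1500 nM with an expected range from 400 nM to 6000 nM around it.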

Compound 4, half-maximal inhibitory concentration: 30100 nM
The estimate for compound 4 lay 20-fold (1.30 log units) below the measured number; measured number outside the range, above it.
By their numbers in this assay, from the lowest: compound 1; then compound 3; then compounds 2 and 4 (each within the scatter of the next).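

In this assay this position on the core of compound 1, on an aromatic carbon meta to a fused ring and para to a fused ring, proves far from indifferent: amino in place of hydrogen gives a 15-fold higher number from compound 1 to compound 4 (1.18 log units; beyond the scatter), a large step. Going by these compounds alone, the only earlier step, nitro in place of hydrogen, ran the opposite way with a 5.2-fold lower number from compound 2 to compound 3 (0.71 log units; beyond the scatter), but on another core, so it did not foretell this. Nothing available explains the rise. On these data alone, it remains open whether nitro or a carboxylic acid at this place on the core of compound 1 would raise the number as amino does or lower it.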